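Swapping bromo for methoxy in compound 3

The source may hold more compounds than are shown below. What is called first, only, known or untested is meant among the compounds shown, and "the series" means these compounds.

In a functional assay on KYSE-450 cells (Homo sapiens) for inhibition, read by CCK-8 assay, with a stated time of 48 h (a higher number here means a weaker inhibitor, a lower number a stronger inhibitor), compound 3 `COc1ccc(CN(C(=O)CSC(=S)N2CCN(C(=O)OC(C)(C)C)CC2)c2ccc(Br)cc2)cc1` gives > 20000 nM as a limit and not a number. Compound 4 `COc1ccc(CN(C(=O)CSC(=S)N2CCN(C(=O)OC(C)(C)C)CC2)c2ccc(OC)cc2)cc1` carries one change, methoxy in place of bromo on an aromatic carbon. The closest measured change is methoxy in place of methyl on an aromatic carbon, on a different core: compound 1 `COc1ccc(CN(C(=O)CSC(=S)N2CCCc3cc(C)ccc32)c2cc(OC)c(OC)c(OC)c2)cc1` gives 5210 nM and compound 2 `COc1ccc(CN(C(=O)CSC(=S)N2CCCc3cc(OC)ccc32)c2cc(OC)c(OC)c(OC)c2)cc1` gives 5530 nM in the same test. That is a 1.1-fold higher number from compound 1 to compound 2 (0.03 log units; within the scatter) and so a small step, though bromo is not what leaves there. No step beyond the scatter is therefore expected in this assay for this swap. The estimated step is a number no higher from compound 3 to compound 4 (the limit leaves the size open) and rests on that single comparison. For compound 4 the expected value is 20000 nM with a range from 8000 nM to 50000 nM and another limit is quite possible.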

Compound 4, half-maximal inhibitory concentration: > 20000 nM
Compound 4: only a limit was reported (the forecaster's own chance of this, stated with the estimate: 60%); the middle value sits exactly at the limit.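

Compound 3 and compound 4 both stop at a limit rather than a number, so no step can be read between them: the limit of > 20000 nM in this assay, at which 2 of the 4 values shown sit. The compounds shown leave open how strongly either acts in this assay, and whether swapping bromo for methoxy changes that.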